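The source may report more compounds than this note shows. Statements on the series, on what has been measured and on what is new or still open speak of the compounds shown alone.

Working notes on the series. Compound 1 `Nc1nc(Cl)c2ncn([C@H]3CCCC[C@H]3CO)c2n1` and compound 2 `Nc1nc2c(nc(Cl)n2COCCO)c(=O)[nH]1` differ by more than one place; the difference between the two cores is not broken down here. In an ADME assay on L1210/0 cells (Mus musculus) for cytotoxicity, with a stated time of 48 h (on this read-out higher numbers stand for weaker inhibition and lower numbers for stronger inhibition), compound 1 gives only a limit, > 200000 nM. In this assay compound 2 likewise gives only a limit, > 200000 nM. Compound 3 `Nc1nc2c(nc(O)n2COCCO)c(=O)[nH]1` arises from compound 2 by hydroxy in place of chloro on an aromatic carbon. In this assay compound 3 also gives only a limit, > 200000 nM. The step that the two limits leave unreadable from compound 2 to compound 3 cannot be sized, since (the limit of > 200000 nM in this assay, at which 3 of the 3 values shown sit).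

Compound 4 `Nc1nc(O)c2ncn([C@H]3CCCC[C@H]3CO)c2n1` arises from compound 1 by hydroxy in place of chloro on an aromatic carbon. This is the same kind of change as that from compound 2 to compound 3, not the same: there the place is on a five-membered aromatic ring with 2 nitrogen, between two ring nitrogen atoms, next to the ring atom that bears a (2-hydroxyethoxy)methyl group, whereas here it is on a six-membered aromatic ring with 2 nitrogen, next to the ring nitrogen, ortho to a fused ring, meta to a fused ring, meta to an amino group, opposite the ring nitrogen. For compound 4 in this assay the expected step is a step that the limit leaves unreadable from compound 1 to compound 4, resting on the unreadable a step that the two limits leave unreadable from compound 2 to compound 3 and on (the limit of > 200000 nM in this assay, at which 3 of the 3 values shown sit). Compound 4 is estimated at 300000 nM, most probably again only a limit.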

Compound 4, half-maximal inhibitory concentration: > 200000 nM
Compound 4 gave a limit, no number (the forecaster's own chance of this, stated with the estimate: 90%); the middle value is on the limit's open side.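

No step can be read between compound 1 and compound 4, since both give only a limit in this assay: the limit of > 200000 nM in this assay, at which 4 of the 4 values shown sit. The compounds shown leave open whether hydroxy in place of chloro on an aromatic carbon changes the read-out in this assay at all, on either core.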